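Pyridinyl for Phenyl on the Indolyl-Bearing Core

This account rests on a few compounds, and the source may have more. Where it says the series, first, only, none or still open, it means among the compounds named here.

Three compounds built on one shared core were measured in a functional assay on SK-BR-3 cells (Homo sapiens) for inhibition, read by sulforhodamine B assay, with a stated time of 48 h; a lower number here means a stronger inhibitor, a higher number a weaker inhibitor. Compound 3 `CO[C@@H]1CC=C2NN(c3ccc(C)cc3)C(=O)C[C@]2(c2ccccc2)O1` gives 9200 nM. Compound 1 `CO[C@@H]1CC=C2NN(c3ccc(C)cc3)C(=O)C[C@]2(c2ccncc2)O1` gives 6200 nM. Compound 2 `CO[C@@H]1CC=C2NN(c3cc4ccccc4[nH]3)C(=O)C[C@]2(c2ccccc2)O1` gives 530 nM, the lowest of the three numbers, with its steps to compound 1 and to compound 3 both beyond the scatter.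

The core of compound 2 differs from the core of compound 3 by 1H-indol-2-yl in place of 4-methylphenyl on an amide-type nitrogen in a ring. Running that change backwards, the step of a 17-fold higher number from compound 2 to compound 3 (1.24 log units; beyond the scatter) was large.

The change pyridin-4-yl in place of phenyl on a saturated ring carbon gave the step of a 1.5-fold lower number from compound 3 to compound 1 (0.17 log units; within the scatter), which is within the scatter.

Compound 4 `CO[C@@H]1CC=C2NN(c3cc4ccccc4[nH]3)C(=O)C[C@]2(c2ccncc2)O1` has not yet been measured in this assay. It differs from compound 2 by pyridin-4-yl in place of phenyl on a saturated ring carbon. The place of this change is described in the same words as for the change from compound 3 to compound 1, so the two changes are the same change, made on cores that differ by the indolyl-for-methylphenyl exchange described above.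

Because the earlier step of a 1.5-fold lower number from compound 3 to compound 1 (0.17 log units; within the scatter) lay within the scatter, compound 4 is expected to stay close to compound 2, with an expected step of a 1.2-fold lower number from compound 2 to compound 4 (0.07 log units; within the scatter). The estimate for compound 4 in this assay is 450 nM, expected to fall between 150 nM and 1500 nM.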

Compound 4, half-maximal inhibitory concentration: 150 nM
Beside the measured number, compound 4's estimate is 3.0-fold (0.48 log units) above it; low and high end bracket the measured number.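

In this assay, pyridin-4-yl in place of phenyl on the saturated ring carbon gave a 3.5-fold lower number from compound 2 to compound 4 (0.55 log units; beyond the scatter), and the two cores compare as follows: the same change on two cores in this assay, a 1.5-fold lower number (0.17 log units; within the scatter) from compound 3 to compound 1 and a 3.5-fold lower number (0.55 log units; beyond the scatter) from compound 2 to compound 4, 2.4-fold (0.38 log units) apart, within the scatter of two such steps. The exchange of 4-methylphenyl for 1H-indol-2-yl on the amide-type nitrogen in the ring also held on the pyridin-4-yl core, with a 41-fold lower number from compound 1 to compound 4 (1.62 log units; beyond the scatter), and its size on the two cores compares as follows: the same change on two cores in this assay, a 17-fold higher number (1.24 log units; beyond the scatter) from compound 2 to compound 3 and a 41-fold higher number (1.62 log units; beyond the scatter) from compound 4 to compound 1, 2.4-fold (0.38 log units) apart, within the scatter of two such steps. Each change therefore carried from one core to the other with no difference beyond the scatter, even though the pyridin-4-yl step lies beyond the scatter on one core and within it on the other; this does not show that the indolyl-bearing core responds more strongly to that change, and a single pair of cores for each change sets no rule for the wider series.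

The compounds shown leave open whether a thienyl or pyrimidinyl group on the saturated ring carbon would follow pyridin-4-yl. They also leave open how an ethoxy group or a longer chain in place of the methoxy group, or an amine on the 1H-indol-2-yl group, would act on either core.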